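This account rests on a few compounds, and the source may have more. Where it says the series, first, only, none or still open, it means among the compounds named here.

Measured so far in a functional assay on HGC-27 cells (Homo sapiens) for inhibition, read by MTT assay, with a stated time of 72 h; a higher number here means a weaker inhibitor, a lower number a stronger inhibitor:

compound 1 `Cc1cc(N2CC[C@@H](C)[C@@H](N(C)c3ncnc4[nH]ccc34)C2)n2nc(SCc3nc4ccccc4[nH]3)nc2n1` — > 100000 nM
compound 2 `Cc1nc2nc(SCc3ccc(Cl)cc3)nn2c(N2CC[C@@H](C)[C@@H](N(C)c3ncnc4[nH]ccc34)C2)c1C` — > 100000 nM

Compound 1 gives > 100000 nM in this assay, and that figure is a limit of the assay, not a number. Compound 2 gives > 100000 nM in this assay, again a limit rather than a number. Compound 1 therefore stands at the edge of what the assay can report, with no measured number of its own; the evidence amounts to the limit of > 100000 nM in this assay, at which 2 of the 2 values shown sit. Among the measured compounds shown here, since neither compound has a real number, no measured step can be drawn between them.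

Compound 3 `Cc1cc(N2CC[C@@H](C)[C@@H](N(C)c3ncnc4[nH]ccc34)C2)n2nc(SCc3ccc(Br)cc3)nc2n1` has not yet been measured. It differs from compound 1 in one place: 4-bromophenyl in place of 1H-benzimidazol-2-yl on a saturated chain carbon bound to a sulfur. Compound 2, a related structure with a halogenated benzyl group on a differently substituted core, also sits at the limit, which gives no sign that such a change unlocks activity. The step from compound 1 to compound 3 is expected to be a number no higher from compound 1 to compound 3 (the limit leaves the size open), which is to say nothing beyond the scatter. Compound 3 is therefore expected to give about 100000 nM in this assay, within the range 30000 nM to 300000 nM, most probably reported again as a limit.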

Compound 3, half-maximal inhibitory concentration: 19500 nM
For compound 3 the middle estimate is 5.1-fold (0.71 log units) above the measured one; measured number outside the range, below it.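

In this assay, the group on the saturated chain carbon bound to a sulfur proves able to move the result: 4-bromophenyl in place of 1H-benzimidazol-2-yl gives an at least 5.1-fold lower number from compound 1 to compound 3 (0.70 log units; beyond the scatter). This is the first real number among the compounds shown, so this position responds to change, and the core of compound 1 can give a measurable result once this group is replaced. The true size of the step stays unknown because compound 1 has only a limit and not a number of its own: the limit of > 100000 nM in this assay, at which 2 of the 3 values shown sit.

The change also swaps a pair of fused rings, with 1 hydrogen-bond donor and 1 hydrogen-bond acceptor, for a single carbon ring bearing bromine, so the compounds shown cannot say which part of this swap matters. An unsubstituted benzyl group would show whether the bromine is needed at all, while a 4-methoxybenzyl group would show whether another group in its place gives a similar result.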